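This account rests on a few compounds, and the source may have more. Where it says the series, first, only, none or still open, it means among the compounds named here.

Measured so far:
- compound 1, `S=C(N/N=C/c1cccs1)Nc1cccnc1`: 45900 nM
- compound 2, `Cc1ccc(NC(=S)N/N=C/c2cccs2)cc1`: 80600 nM

In a functional assay on NCI-H460 cells (Homo sapiens) for inhibition, read by sulforhodamine B assay, with a stated time of 48 h (on this read-out lower numbers stand for stronger inhibition of growth and higher numbers for weaker inhibition of growth), compound 1 gives 45900 nM and compound 2 gives 80600 nM; these two numbers lie within the usual scatter of each other, so neither compound can be set apart from the other on this read-out. Compound 3, `S=C(N/N=C/c1cccs1)Nc1ccc(Br)cc1`, has not yet been measured. It differs from compound 2 in one place: bromo in place of methyl on an aromatic carbon. Going by the values given here, the two numbers known so far are close to each other, so no step beyond the scatter is expected. For compound 3 the expected step in this assay is a 1.3-fold lower number from compound 2 to compound 3 (0.13 log units; within the scatter), and its estimated value is 60000 nM, within 20000 nM to 180000 nM.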

Compound 3, concentration for 50% growth inhibition: 4700 nM
The estimate for compound 3 lay 13-fold (1.11 log units) above the measured number, and the stated range ends above it.
By their numbers in this assay, from the lowest: compound 3; then compounds 1 and 2 (each within the scatter of the next).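

In this assay, putting bromo in place of methyl on the aromatic carbon para to a large group gives a 17-fold lower number from compound 2 to compound 3 (1.23 log units; beyond the scatter), so a change of one heavy atom at this place can move growth inhibition well beyond the scatter. The two earlier compounds, whose numbers lie within the scatter of each other, did not show this. No measurement here accounts for the step. Only this one exchange at this place is shown, so how chloro, an amine or a carboxylic acid there would read in this assay remains open.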